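The source may report more compounds than this note shows. Statements on the series, on what has been measured and on what is new or still open speak of the compounds shown alone.

Measured compounds and their values in a functional assay on SNB-75 cells (Homo sapiens) for inhibition, read by sulforhodamine B assay, with a stated time of 48 h, tested at 10 uM; a higher number here means a weaker effect of the compound at the concentration tested, a lower number a stronger effect:

Compound 1, `COc1cc2cc(Oc3ccc(NC(=O)Nc4ccc(C)cc4)cc3)c(C)nc2cc1OC`: 56.3%
Compound 2, `COc1cc2cc(Oc3ccc(NC(=O)Nc4ccc(C(F)(F)F)cc4)cc3)c(C)nc2cc1OC`: 41%

Among the compounds with values here, of these two numbers compound 2 stands lowest; its nearest neighbour is compound 1, and the step of a number 15.3 percentage points lower from compound 1 to compound 2 (beyond the scatter) is the only measured step in this set, trifluoromethyl in place of methyl on an aromatic carbon.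

Compound 3, `COc1cc2cc(Oc3ccc(NC(=O)Nc4cccc(C(F)(F)F)c4)cc3)c(C)nc2cc1OC`, has not yet been measured. It differs from compound 2 by 3-(trifluoromethyl)phenyl in place of 4-(trifluoromethyl)phenyl on an amide-type nitrogen. Within the data shown here, that is a rearrangement of the same atoms, whereas the one measured step exchanges one group for another; it therefore gives no guidance on the direction for compound 3. With nothing to point one way or the other, the expected step of a number 4 percentage points higher from compound 2 to compound 3 (within the scatter) is none beyond the scatter, though a modest shift in either direction cannot be ruled out. Compound 3 is thus estimated at 45%, within a range of 25% to 65%.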

Compound 3, a percentage reported as activity, at one concentration (the size of the read-out at that concentration, not a potency): 13.1%
Compound 3: the middle estimate sits 31.9 percentage points above what was measured; measured number below the stated range.
By their numbers in this assay, from the lowest: compound 3; then compound 2; then compound 1.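

In this assay, moving the trifluoromethyl group to another place on the same phenyl ring, with no atom gained or lost, gives a number 27.9 percentage points lower from compound 2 to compound 3 (beyond the scatter). On this amide-type nitrogen, then, the arrangement of the atoms in the aromatic group matters, not only which atoms it carries. Exchanging 4-methylphenyl for 3-(trifluoromethyl)phenyl on the same nitrogen gives a number 43.2 percentage points lower from compound 1 to compound 3 (beyond the scatter), leaving compound 3 with the strongest effect of the three at the concentration tested, and nothing measured here accounts for the effect of the rearrangement.

From the compounds shown here alone, whether such a rearrangement has a similar effect with any group other than trifluoromethyl stays open, since these compounds show it for this group alone. A chlorine, a nitrile or an amine in its place would test how far the result reaches.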